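The source may hold more compounds than are shown below. What is called first, only, known or untested is meant among the compounds shown, and "the series" means these compounds.

Compound 1 `CN(C)c1ccc(/C=C(/SCc2ccc(Cl)cc2Cl)C(=O)c2ccc(Cl)cc2)cc1` and compound 2 `Cc1ccc(CS/C(=C/c2ccc(N(C)C)cc2)C(=O)c2ccc(Cl)cc2)cc1` share one core and differ only in the group carried on the saturated chain carbon bound to a sulfur. In a functional assay on DU-145 cells (Homo sapiens) for inhibition, read by trypan blue exclusion, with a stated time of 96 h (on this read-out higher numbers stand for weaker inhibition of growth and lower numbers for stronger inhibition of growth), compound 1 gives 50000 nM. Compound 2 gives > 100000 nM, which is a limit of the assay and not a number, so only a limit is known for compound 2. The step of an at least 2.0-fold higher number from compound 1 to compound 2 (0.30 log units; that floor lies within the scatter) therefore rests on the limit of > 100000 nM in this assay, at which 1 of the 2 values shown sits, and cannot be sized beyond its floor.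

Compound 3 `COc1ccccc1/C=C(/SCc1ccc(C)cc1)C(=O)c1ccc(Cl)cc1` differs from compound 2 at a different place: 2-methoxyphenyl in place of 4-(dimethylamino)phenyl on a double-bonded chain carbon bound to a double-bonded chain carbon. Among the compounds with values here, no measured step touches this part of the molecule; the one measured step, an at least 2.0-fold higher number from compound 1 to compound 2 (0.30 log units; that floor lies within the scatter), concerns the group on the saturated chain carbon bound to a sulfur and says nothing about the aryl group on the double-bonded chain carbon. With both measured values weak and one of them only a limit, the estimate for compound 3 is a step of a number no higher from compound 2 to compound 3 (the limit leaves the size open), meaning no change beyond the scatter is expected. Compound 3 is accordingly expected to give about 100000 nM, with a range from 30000 nM to 300000 nM, and a fair chance that this assay again reports only a limit.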

Compound 3, concentration for 50% growth inhibition: 10000 nM
Compound 3: the middle estimate sits 10-fold (1.00 log units) above what was measured; measured number below the stated range.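

Swapping 4-(dimethylamino)phenyl for 2-methoxyphenyl on a double-bonded chain carbon bound to a double-bonded chain carbon gives, in this assay, an at least 10-fold lower number from compound 2 to compound 3 (1.00 log units; beyond the scatter). The only earlier step concerned the group on the saturated chain carbon bound to a sulfur and had a floor within the scatter, so this is the first step shown to go beyond the scatter, and it places a measurable effect on growth inhibition at this aryl position. For compound 2, the value > 100000 nM is a limit of the assay and not a number, so the step gives only a floor and its true size stays open: the limit of > 100000 nM in this assay, at which 1 of the 3 values shown sits.

A single swap cannot separate the loss of the dimethylamino group from the arrival of the methoxy group, so it remains unclear which of the two drives the step. Also open, as far as these compounds go, are whether 2-methoxyphenyl would give a similar step alongside the 2,4-dichlorophenyl of compound 1, and how an unsubstituted phenyl, or a phenyl bearing a hydroxyl or a primary amine, would behave at this place.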